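The source may hold more compounds than are shown below. What is called first, only, known or untested is meant among the compounds shown, and "the series" means these compounds.

Compound 2 `COc1ccc(-n2c(SC(C)C(=O)Nc3nc(C)cs3)nc3ccccc32)cc1` is the starting point of this account, and in an ADME assay on Vero cells (Chlorocebus sabaeus) for cytotoxicity, read by MTT assay, with a stated time of 24 h (a higher number here means that more compound is tolerated, a lower number that less compound is tolerated), compound 2 is recorded as "not determined" (no result reported). Compound 1 `COc1ccc(-n2c(SC(C)C(=O)Nc3nnc(C)c(C)n3)nc3ccccc32)cc1` is in the same position: in this assay compound 1 is recorded as "not determined" (no result reported). Among the compounds with values here, of the three compounds measured so far, only compound 3 `COc1ccc(-n2c([S+]([O-])C(C)C(=O)Nc3ccc(C)cc3Cl)nc3ccccc32)cc1` gives a result, and that result is a limit of the assay rather than a number: in this assay compound 3 reaches > 75000 nM. So compound 2 stands nowhere on the numbers, since there is no number for it, and the only reading at all sits at the edge of the assay, (the limit of > 75000 nM in this assay, at which 1 of the 3 values shown sits).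

Compound 4 `COc1ccc(-n2c(SC(C)C(=O)Nc3ccc(C)cc3Cl)nc3ccccc32)cc1` is formed from compound 2 by 2-chloro-4-methylphenyl in place of 4-methyl-1,3-thiazol-2-yl on an amide-type nitrogen. Within the data shown here, no measured pair shows what such a change does in this assay, so no direction can be read from the data; the one measured compound, compound 3, carries the same 2-chloro-4-methylphenyl and sits at the limit. On that slender basis compound 4 is expected to be tolerated at about 80000 nM, somewhere between 30000 nM and 200000 nM, with a fair chance that only a limit is reported.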

Compound 4, half-maximal cytotoxic concentration: > 75000 nM
Compound 4: a limit, no number (the forecaster's own chance of this, stated with the estimate: 65%); the middle value does not contradict the limit.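

In this assay compound 4 gives > 75000 nM, a limit of the assay and not a number. Compound 2 has no result, so no step can be read between compound 2 and compound 4. The compounds shown leave open what concentration any of them actually tolerates, and whether the change of amide substituent matters.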